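Removing the chloro from compound 2

A few compounds are considered here, and "the series" means these few. Any claim that something is new, unique, unknown or untested is made for them only; others in the source may bear on it.

Measured in a functional assay on PC-3 cells (Homo sapiens) for cytotoxicity, read by MTT assay, with a stated time of 72 h; on this read-out higher numbers stand for weaker inhibition and lower numbers for stronger inhibition:
Compound 1 `CNC(=O)c1cc(Oc2ccc(C(=O)/C=C/c3ccc([N+](=O)[O-])cc3)cc2)ccn1`: 11100 nM
Compound 2 `CNC(=O)c1cc(Oc2ccc(C(=O)/C=C/c3ccc(F)cc3Cl)cc2)ccn1`: 4760 nM

Among the measured compounds shown here, compound 2 holds the lower of the two numbers, and the only measured step is a 2.3-fold lower number from compound 1 to compound 2 (0.37 log units; beyond the scatter). That step put 2-chloro-4-fluorophenyl in place of 4-nitrophenyl. Compound 3 `CNC(=O)c1cc(Oc2ccc(C(=O)/C=C/c3ccc(F)cc3)cc2)ccn1` departs from compound 2 by hydrogen in place of chloro on an aromatic carbon, so that 2-chloro-4-fluorophenyl becomes 4-fluorophenyl. For the measured compounds named here, no measured pair isolates the chloro alone. Going by the values given here, the single step, a 2.3-fold lower number from compound 1 to compound 2 (0.37 log units; beyond the scatter), bears on the change only loosely. It also removed the nitro group. A modest move toward a higher number is therefore expected, no larger than about that step, though a result within the scatter would not be surprising. The expected shift is a 1.4-fold higher number from compound 2 to compound 3 (0.14 log units; within the scatter). For compound 3 the estimated value is 6500 nM, with an expected range of 2800 nM to 15000 nM.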

Compound 3, half-maximal inhibitory concentration: 6140 nM
Compound 3: middle estimate off by 1.1-fold (0.02 log units), on the high side, within the range that was stated.
By their numbers in this assay, from the lowest: compounds 2, 3 and 1 (each within the scatter of the next, the first and the last beyond it).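

In this assay, among the compounds shown here, taking the chloro off the aromatic carbon gives a 1.3-fold higher number from compound 2 to compound 3 (0.11 log units; within the scatter), so this pair isolates the chloro for the first time and shows that, on this carbon, it cannot be told apart from hydrogen. With the chloro absent, the same compound also isolates the other half of the earlier double change: a 1.8-fold lower number from compound 1 to compound 3 (0.26 log units; within the scatter), likewise no separable effect of fluoro in place of nitro, although the two changes together gave a 2.3-fold lower number from compound 1 to compound 2 (0.37 log units; beyond the scatter). No evidence is available to explain these numbers.

The compounds shown leave open whether a bromo or methoxy group on this same carbon would move the number beyond the scatter. They also leave open whether an amine in place of the fluoro would do so.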